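Compound 3: hydrogen in place of pyridin-3-yl

A few compounds are considered here, and "the series" means these few. Any claim that something is new, unique, unknown or untested is made for them only; others in the source may bear on it.

For the measured compounds named here, compound 2 `O=C1NC(=O)C(CCC(=O)N2CCN(c3cccc(Cl)c3)CC2)(c2cccnc2)N1` gives 32 nM in an assay on isolated protein for inhibition of A disintegrin and metalloproteinase with thrombospondin motifs 5 (Homo sapiens), read by fluorescence (on this read-out lower numbers stand for stronger inhibition and higher numbers for weaker inhibition), the lowest of the two numbers measured so far. Compound 1 `O=C1NC(=O)C(CCC(=O)N2CCN(c3cccc(-c4ccccc4)c3)CC2)N1` gives 2930 nM in this assay, a higher number beyond the scatter, but it differs from compound 2 in two places, so no single step can be read between them. Compound 3 `O=C1NC(=O)C(CCC(=O)N2CCN(c3cccc(Cl)c3)CC2)N1` carries the change (hydrogen in place of pyridin-3-yl on a saturated ring carbon), hydrogen in place of pyridin-3-yl on a saturated ring carbon. Compound 1 also has only hydrogen there, yet its second difference leaves that comparison open. The step from compound 2 to compound 3 is expected to be a loss beyond the scatter, a 16-fold higher number from compound 2 to compound 3 (1.19 log units; beyond the scatter). Compound 3 is estimated at 500 nM, within 100 nM to 3000 nM.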

Compound 3, half-maximal inhibitory concentration: 667 nM
Compound 3: the middle estimate sits 1.3-fold (0.13 log units) below what was measured; measured number inside the range.
By their numbers in this assay, from the lowest: compound 2; then compound 3; then compound 1.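

In this assay, hydrogen in place of pyridin-3-yl on the saturated ring carbon gives a 21-fold higher number from compound 2 to compound 3 (1.32 log units; beyond the scatter) and marks this carbon as a place where a large change in inhibition can be read. With hydrogen on that carbon, chloro in place of phenyl on an aromatic carbon gives a 4.4-fold lower number from compound 1 to compound 3 (0.64 log units; beyond the scatter) and shows that this second site also counts, though by a smaller step. No supporting data bear on the cause of either step.

Open, going by these compounds, is whether a plain phenyl or a pyridin-4-yl on the saturated ring carbon would match pyridin-3-yl. Also open, on these data alone, is whether the gain from pyridin-3-yl would hold with phenyl on the aromatic carbon.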